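The source may report more compounds than this note shows. Statements on the series, on what has been measured and on what is new or still open speak of the compounds shown alone.

- Compound 1 `CCCC[C@@]12O[C@]34CCCC=C3C(=O)O[C@@]43[C@H](CCC)[C@H]4C=C(C(=O)N1[C@H](C)c1ccccc1)[C@]32CC4`: 5900 nM
- Compound 2 `CCCC[C@]12O[C@@]34CCCC=C3C(=O)O[C@]43[C@@H](CCC)[C@@H]4C=C(C(=O)N1[C@H](C)c1ccccc1)[C@@]32CC4`: 4100 nM

In a functional assay on SK-LU-1 cells (Homo sapiens) for inhibition, read by sulforhodamine B assay, with a stated time of 48 h (a lower number here means a stronger inhibitor, a higher number a weaker inhibitor), compound 2 gives 4100 nM. Among the measured compounds shown here, this lies within the scatter of the only other measured compound, compound 1, so the two cannot be ranked.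

Compound 3 `CCCC[C@@]12O[C@]34CCCC=C3C(=O)O[C@@]43[C@H](CCC)[C@@H]4C=C(C(=O)N1[C@@H](C)c1ccccc1)[C@]32CC4` has not yet been measured. Nothing leaves and nothing enters on going to it from compound 2: the two compounds have the same atoms and bonds and differ only in configuration as drawn: 6 of 7 stereo elements differ; a stereocentre at a saturated ring carbon is drawn R in compound 2 and S in compound 3; a stereocentre at a saturated ring carbon is drawn S in compound 2 and R in compound 3; a stereocentre at a saturated ring carbon is drawn S in compound 2 and R in compound 3; a stereocentre at a saturated ring carbon is drawn S in compound 2 and R in compound 3.

For the measured compounds named here, the one measured step that bears on this change is a 1.4-fold lower number from compound 1 to compound 2 (0.16 log units; within the scatter). It is relevant because of the fact that compounds 1 and 2 differ only in the configuration as drawn. That step stayed within the scatter, so no step beyond the scatter is expected in this assay, in either direction. A single step is thin evidence, however, so the range is kept wide.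

The estimated change is a 1.1-fold higher number from compound 2 to compound 3 (0.04 log units; within the scatter). For compound 3 the expected value is 4500 nM, with an expected range of 1800 nM to 11000 nM.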

Compound 3, half-maximal inhibitory concentration: 4900 nM
Compound 3: middle estimate off by 1.1-fold (0.04 log units), on the low side, and the stated range covers the measured number.
By their numbers in this assay, from the lowest: compounds 2, 3 and 1 (each within the scatter of the next).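

In this assay, compound 3 cannot be told apart from either earlier compound: the data show a 1.2-fold higher number from compound 2 to compound 3 (0.08 log units; within the scatter) and a 1.2-fold lower number from compound 1 to compound 3 (0.08 log units; within the scatter). The second step changes only 2 of 7 stereo elements, one at a saturated ring carbon and one at a saturated chain carbon, while the first changes 6 of 7, and both remain within the scatter. With three compounds instead of two, neither the smaller nor the larger change in configuration separates them, and these comparisons involve no change of group: the fact that compounds 2 and 3 differ only in the configuration as drawn

All three compounds carry the same groups, so they leave open whether changing a group would move the number beyond the scatter. An amine or a carboxylic acid on the shared core would be one such change, and its effect cannot be judged from these compounds.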